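Swapping the aryl group on a thiazole-based DP2 antagonist

This account rests on a few compounds, and the source may have more. Where it says the series, first, only, none or still open, it means among the compounds named here.

Measured so far:
- Compound 1, `O=C(O)Cc1sc(C(c2ccccc2)c2ccccc2)nc1-c1cccc(F)c1`: 29 nM
- Compound 2, `COc1ccc(OC)c(-c2nc(C(c3ccccc3)c3ccccc3)sc2CC(=O)O)c1`: > 100000 nM
- Compound 3, `NS(=O)(=O)c1cccc(-c2nc(C(c3ccc(F)cc3)c3ccc(F)cc3)sc2CC(=O)O)c1`: 710 nM

Three compounds share one core and were tested in an in vitro functional assay on HEK285-7 cells for antagonist activity at prostaglandin D2 receptor 2 (Homo sapiens), read by BRET and beta-arrestin recruitment; on this read-out lower numbers stand for stronger inhibition and higher numbers for weaker inhibition. Compound 1 gives 29 nM. Compound 2 reaches only a limit of the assay, > 100000 nM, so no number is known for it. Compound 3 gives 710 nM, the highest of the two numbers shown; compound 1 sits well below it.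

Compound 4, `CN(C)c1cc(-c2nc(C(c3ccc(F)cc3)c3ccc(F)cc3)sc2CC(=O)O)ccn1`, is not yet measured. It differs from compound 3 in one place:

2-(dimethylamino)pyridin-4-yl in place of 3-sulfamoylphenyl on an aromatic carbon

For the measured compounds named here, only one measured step changes the same part of the core: an at least 3400-fold higher number from compound 1 to compound 2 (3.53 log units; beyond the scatter). That step shows the aryl group on this position can move the number a long way, but it involves different groups, so it gives no direction for the present change. Compound 4 is expected to give roughly 300 nM, within a wide range from 30 nM to 3000 nM. This would be an estimated 2.4-fold lower number from compound 3 to compound 4 (0.37 log units; beyond the scatter).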

Compound 4, half-maximal inhibitory concentration: > 100000 nM
Compound 4: no number, only a limit; the forecaster's own chance of this, stated with the estimate: 10%; middle value at least 330-fold (2.52 log units) away from the limit.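

Replacing 3-sulfamoylphenyl with 2-(dimethylamino)pyridin-4-yl, on the aromatic carbon next to the ring nitrogen, gives an at least 140-fold higher number from compound 3 to compound 4 (2.14 log units; beyond the scatter). The earlier loss of this kind came with 2,5-dimethoxyphenyl, so among the compounds shown, a loss this large is not tied to that one group, and two quite different aryl groups can both produce it. Compound 4 gives a limit of the assay rather than a number, and compound 2 gives a limit too: the limit of > 100000 nM in this assay, at which 2 of the 4 values shown sit.

Going by these compounds, the change alters several things at once: it puts a nitrogen into the ring, adds a dimethylamino group and removes the sulfamoyl group with its hydrogen-bond donor, so which of these matters remains open. A plain pyridine ring without the dimethylamino group, or a phenyl ring carrying a dimethylamino group, would help to tell these apart.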